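The source may report more compounds than this note shows. Statements on the series, on what has been measured and on what is new or still open speak of the compounds shown alone.

Measured compounds:
compound 1 `CC1=C(C(=O)OCc2ccccc2)C(c2ccco2)NC(=O)N1` — in an assay on membranes from CHO cells for displacement of a labelled ligand from adenosine receptor A1 (Homo sapiens), read by scintillation counting, with a stated time of 60 min, tested at 1 uM (on this read-out higher numbers stand for more inhibition at the one concentration tested (going by the name of the read-out) and lower numbers for less inhibition), compound 1 gives 36%
compound 2 `CCC(CC)OC(=O)C1=C(C)NC(=O)NC1c1ccco1` — in this assay compound 2 gives 2%

Among the measured compounds shown here, compound 2 stands lowest of the two numbers; its nearest neighbour is compound 1, and the only measured step, a number 34 percentage points lower from compound 1 to compound 2 (beyond the scatter), is a large fall that lies beyond the scatter. For the measured compounds named here, compound 3 `CC1=C(C(=O)OC2CCC2)C(c2ccco2)NC(=O)N1` differs from compound 2 by cyclobutyl in place of pentan-3-yl on an oxygen next to a carbonyl group, at the same oxygen where the one measured step was taken. That step concerned a different pair of groups, benzyl and pentan-3-yl, so it only shows that this position can move the read-out strongly; it does not show what cyclobutyl will do. Going by the values given here, with compound 2 already near the bottom of the scale and no step for cyclobutyl available, compound 3 is expected to change by a number 6 percentage points higher from compound 2 to compound 3 (within the scatter), a step not beyond the scatter. The estimate for compound 3 in this assay is 8%, within 0% to 25%.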

Compound 3, a percentage reported as inhibition, at one concentration (the size of the read-out at that concentration, not a potency): 19%
Beside the measured number, compound 3's estimate is 11 percentage points below it; the range from low to high includes it.
By their numbers in this assay, from the lowest: compound 2; then compound 3; then compound 1.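

In this assay, cyclobutyl in place of pentan-3-yl on the oxygen next to a carbonyl group gives a number 17 percentage points higher from compound 2 to compound 3 (beyond the scatter) and thereby shows that a change between two groups of carbon only, neither with a hydrogen-bond donor or acceptor, can still move the read-out at this position. Cyclobutyl in place of benzyl gives a number 17 percentage points lower from compound 1 to compound 3 (beyond the scatter) so the three groups fall on three separate levels, and the position does not act as a simple switch between two. Nothing given here explains this order.

Among the compounds shown here, with only three groups, all of carbon only, it stays open whether a ring is what separates compound 1 and compound 3 from compound 2. From the compounds shown here alone, how an amine, a carboxylic acid or a longer straight chain on this oxygen would read also remains open.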